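Swapping the bicyclic amide group on compound 1

This account rests on a few compounds, and the source may have more. Where it says the series, first, only, none or still open, it means among the compounds named here.

Measured so far in an ADME assay on microsomes from liver (Mus musculus) for metabolic stability, read by LC-MS, with a stated time of 30 min, tested at 1 uM; a higher number here means that more of the compound is left, a lower number that less of the compound is left
compound 1 `O=C(NCc1ccc(S(=O)(=O)c2ccccc2)cc1)c1cc2ccncc2s1` gives 21%
compound 2 `O=C(NCc1ccc(S(=O)(=O)c2cccc(F)c2)cc1)c1cc2cnccc2[nH]1` gives 44%
compound 3 `O=C(NCc1ccc(S(=O)(=O)N2CCCCC2)cc1)c1cnc2nccn2c1` gives 0.28%

Compound 1 (21%) stands in the middle of the three numbers. Compound 2 (44%) lies higher and compound 3 (0.28%) lies lower, each beyond the usual scatter from compound 1.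

Compound 4 `O=C(NCc1ccc(S(=O)(=O)c2ccccc2)cc1)c1cn2ccnc2cn1` has not yet been measured in this assay. Its change from compound 1 is a group of 9 heavy atoms (6 carbon, 3 nitrogen; one five-membered aromatic ring with 2 hetero atoms, one six-membered aromatic ring with 2 hetero atoms) in place of a group of 9 heavy atoms (7 carbon, 1 nitrogen, 1 sulfur; one five-membered aromatic ring with 1 hetero atom, one six-membered aromatic ring with 1 hetero atom), on a carbonyl carbon and it sits on a carbonyl carbon, with the rest of the structure untouched.

For the measured compounds named here, no pair of measured compounds differs in one place only, so the data hold no direct precedent for this swap. The nearest hint is compound 3 (0.28%), which also carries a five-membered and a six-membered aromatic ring with more than one hetero atom on its carbonyl carbon. However, it differs from compound 1 in a second place as well, so it supports only a slight lean downward. The estimated step is a number 6 percentage points lower from compound 1 to compound 4 (within the scatter) and it is expected to stay within the usual scatter, though the uncertainty is wide. For compound 4 the estimated value is 15% (expected range 3% to 42%).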

Compound 4, percent of the compound remaining: 13%
Compound 4: the middle estimate sits 2 percentage points above what was measured; low and high end bracket the measured number.
By their numbers in this assay, from the lowest: compound 3; then compounds 4 and 1 (each within the scatter of the next); then compound 2.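

In this assay, for the compounds shown here, the one single-place comparison at the carbonyl carbon reads a number 8 percentage points lower from compound 1 to compound 4 (within the scatter). This position therefore accepts a group of 9 heavy atoms (6 carbon, 3 nitrogen) in place of a group of 9 heavy atoms (7 carbon, 1 nitrogen, 1 sulfur) without a change that stands clear of the usual scatter, so this swap, which removes the sulfur, does not separate the two compounds in this read-out. No measurement at hand bears on the reason for this result.

From the compounds shown here alone, compounds 2 and 3 each differ from compound 1 in more than one place, so what the group on the carbonyl carbon alone contributes to their values stays open, and a single swap that keeps the rest of the structure fixed says nothing about how wide the tolerated range at this position is. Also open, going by these compounds, is how this assay would read with a morpholine or a carboxylic acid on the bicyclic group of compound 4, with the rest of the structure untouched.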